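The source may hold more compounds than are shown below. What is called first, only, known or untested is meant among the compounds shown, and "the series" means these compounds.

Working notes on the series, read in a functional assay on A549 cells (Homo sapiens) for antiproliferative activity, read by sulforhodamine B assay, with a stated time of 3 days; a lower number here means a stronger inhibitor of growth, a higher number a weaker inhibitor of growth. Compound 1 `COc1ccc(N2CCN(C)CC2)cc1Nc1ncc(F)c(Nc2ccc(F)cc2)n1` gives 1130 nM, while compound 3 `O=C(c1cccc(Nc2ncc(F)c(Nc3ccc(F)cc3)n2)c1)N1CCCCC1` gives 13200 nM, the higher of the two numbers available. Compound 2 `O=C(Nc1ccc(C(F)(F)F)cc1)c1cccc(Nc2ncc(F)c(Nc3ccc(F)cc3)n2)c1` gives > 10000 nM, which is a limit of the assay and not a number. Compound 4 `O=C(Nc1cccc(Nc2ncc(F)c(Nc3ccc(F)cc3)n2)c1)c1ccccc1` is the next to be read, and the change is benzamido in place of (piperidin-1-yl)carbonyl on an aromatic carbon, meta to a large group. Within the data shown here, the only measured step, a step that the limit leaves unreadable from compound 2 to compound 3, has no readable size, so it gives no measure for this change. The expectation therefore stays near compound 3 at 13200 nM, with no shift beyond the scatter in this assay. The expected step is a 1.5-fold lower number from compound 3 to compound 4 (0.17 log units; within the scatter). Compound 4 is estimated at 9000 nM, with an expected range of 3000 nM to 25000 nM.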

Compound 4, concentration for 50% growth inhibition: 37800 nM
Estimate against measurement, compound 4: 4.2-fold (0.62 log units) below, and the stated range ends below it.
By their numbers in this assay, from the lowest: compound 1; then compound 3; then compound 4.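

In this assay, benzamido in place of (piperidin-1-yl)carbonyl on this aromatic carbon gives the first readable size for a change here, a 2.9-fold higher number from compound 3 to compound 4 (0.46 log units; beyond the scatter), and the direction is toward weaker growth inhibition. The change swaps a non-aromatic ring for an aromatic one and adds a hydrogen-bond donor together, so the two cannot be separated. Compound 2 carries a limit, so its step to compound 3 cannot be read: the limit of > 10000 nM in this assay, at which 1 of the 4 values shown sits.

Open, as far as these compounds go, is whether a carboxylic acid or a primary amine on this aromatic carbon would give a lower number.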